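Aryl extension on the fused ring of compound 1

The source may report more compounds than this note shows. Statements on the series, on what has been measured and on what is new or still open speak of the compounds shown alone.

Compound 1 `Cc1[nH]n(-c2nc3cc(Cl)ccc3[nH]2)c(=O)c1Cc1ccccc1` stands highest of the two numbers in a functional assay on DU-145 cells (Homo sapiens) for antiproliferative activity, read by WST assay, with a stated time of 7 days, tested at 1 uM (a lower number here means a weaker effect, a higher number a stronger effect of the compound at the concentration tested), where compound 1 gives 84%. Compound 2 `Cc1nn(-c2nc3ccccc3[nH]2)c(O)c1Cc1ccccc1`, the nearest, gives 42% in this assay, a gap beyond the scatter. Compound 3 `Cc1[nH]n(-c2nc3cc(-c4ccc(Cl)cc4)ccc3[nH]2)c(=O)c1Cc1ccccc1` carries the change (4-chlorophenyl in place of chloro on an aromatic carbon). Going by the values given here, no measured pair shows a change of this kind, so the expectation for compound 3 rests on compound 1 alone, and the step is expected to be none beyond the scatter, with a slight downward lean. The expected step is a number 9 percentage points lower from compound 1 to compound 3 (within the scatter). Compound 3 is estimated at 75%, between 40% and 95%.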

Compound 3, a percentage reported as inhibition, at one concentration (the size of the read-out at that concentration, not a potency): 91%
Beside the measured number, compound 3's estimate is 16 percentage points below it; measured number inside the range.
By their numbers in this assay, from the lowest: compound 2; then compounds 1 and 3 (each within the scatter of the next).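

In this assay, the position on the six-membered aromatic ring takes 4-chlorophenyl in place of chloro with a step of a number 7 percentage points higher from compound 1 to compound 3 (within the scatter), so this much larger group, with its added aromatic ring, is accepted here. Each figure is the size of the effect at one concentration, so the comparison between these two compounds holds only for the effect at that concentration. Nothing measured here explains this tolerance.

Open, on these data alone, is whether the chlorine on the added ring matters, which a plain phenyl would test. Also open, as far as these compounds go, is how an amine or a carboxylic acid on that ring would read.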